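The source may report more compounds than this note shows. Statements on the series, on what has been measured and on what is new or still open speak of the compounds shown alone.

Measured so far:
- compound 1 `O=C(Nc1ccc(Cl)cc1)Nc1nn(-c2ccccc2)c(=O)c2ccccc12`: 13%
- compound 2 `COc1ccc(NC(=O)Nc2nn(-c3ccccc3)c(=O)c3ccccc23)c(OC)c1`: 33%

Compound 2 gives the higher of the two numbers in an assay on CHO cells for displacement of a labelled ligand from adenosine receptor A3 (Homo sapiens), tested at 1 uM; a lower number here means less inhibition, a higher number more inhibition at the concentration tested (going by the name of the read-out); its nearest neighbour is compound 1, and the step of a number 20 percentage points higher from compound 1 to compound 2 (beyond the scatter) lies beyond the usual scatter. The next compound, compound 3 `Cc1ccccc1NC(=O)Nc1nn(-c2ccccc2)c(=O)c2ccccc12`, keeps the shared core and the urea linker and differs from compound 2 only at the aryl group: 2-methylphenyl in place of 2,4-dimethoxyphenyl on an amide-type nitrogen. Among the compounds with values here, the one measured step that bears on this change is a number 20 percentage points higher from compound 1 to compound 2 (beyond the scatter), which shows that the aryl group on this nitrogen can shift the read-out in this assay by a modest amount. Within the data shown here, no measured compound carries a 2-methylphenyl group, so the direction of the new step is uncertain; a change no larger than that single step is expected, more likely downward than upward. The expected step is a number 13 percentage points lower from compound 2 to compound 3 (beyond the scatter). For compound 3 the estimate in this assay is 20%, within 5% to 40%.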

Compound 3, a percentage reported as inhibition, at one concentration (the size of the read-out at that concentration, not a potency): 22%
Beside the measured number, compound 3's estimate is 2 percentage points below it; the range from low to high includes it.
By their numbers in this assay, from the lowest: compounds 1 and 3 (each within the scatter of the next); then compound 2.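

In this assay the swap to 2-methylphenyl on the amide-type nitrogen gives a number 11 percentage points lower from compound 2 to compound 3 (beyond the scatter) and so leaves the 2,4-dimethoxyphenyl group of compound 2 with the highest number of the three aryl groups shown. The other new comparison, a number 9 percentage points higher from compound 1 to compound 3 (within the scatter) on the same nitrogen, shows that 2-methylphenyl and 4-chlorophenyl cannot be told apart here, even though they carry different groups on the ring. Nothing available explains why the 2,4-dimethoxyphenyl group stands apart from these two.

From the compounds shown here alone, it remains open whether a single methoxy group on the phenyl ring would give a number like that of compound 2. Also open, going by these compounds, is how this assay would respond to an amine or a carboxylic acid on that ring, or to a longer alkyl chain in place of the ring.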